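Cycloheptyl in Place of 4-Methoxyphenyl: Expecting No Change

A few compounds are considered here, and "the series" means these few. Any claim that something is new, unique, unknown or untested is made for them only; others in the source may bear on it.

Three compounds share a common core and differ only in the groups attached around it. Compound 1 `COc1ccc(N2CCN(Cc3csc(N)c3C(=O)c3ccc(Cl)cc3)CC2)cc1` carries a 4-methoxyphenyl on an amine nitrogen in a ring. In an assay on CHO cells for displacement of a labelled ligand from adenosine receptor A1 (Homo sapiens), read by scintillation counting, with a stated time of 120 min, tested at 10 uM (a higher number here means more inhibition at the concentration tested (going by the name of the read-out), a lower number less inhibition), compound 1 gives 0%. Compound 2 `Nc1scc(CN2CCC(c3ccc(Cl)cc3)CC2)c1C(=O)c1ccc(Cl)cc1` gives 0% in this assay, and compound 3 `Nc1scc(CN2CCN(c3ccc(C(F)(F)F)cc3)CC2)c1C(=O)c1cccc(C(F)(F)F)c1` gives 0%. Compound 1 thus stands level with compounds 2 and 3 at the digits reported: none of the three shows measurable displacement of the labelled ligand at the concentration tested, and the differences between them lie within the scatter of the method.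

Compound 4 `Nc1scc(CN2CCN(C3CCCCCC3)CC2)c1C(=O)c1ccc(Cl)cc1` has not yet been measured. It differs from compound 1 in one place: cycloheptyl in place of 4-methoxyphenyl on an amine nitrogen in a ring An aromatic ring carrying one hydrogen-bond acceptor leaves, and a seven-membered non-aromatic ring of carbon only, with no hydrogen-bond acceptor, enters. Among the compounds with values here, no pair of measured compounds shows a comparable change, so there is no step to lean on. Compound 1 gives 0%, and compounds 2 and 3 show the same reading, so the change is expected to produce a step of a number 5 percentage points higher from compound 1 to compound 4 (within the scatter), nothing beyond the scatter. Compound 4 is therefore estimated to give 5% in this assay, with a range from 0% to 20%.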

Compound 4, a percentage reported as inhibition, at one concentration (the size of the read-out at that concentration, not a potency): 0%
Estimate against measurement, compound 4: 5 percentage points above; measured number inside the range.
By their numbers in this assay, from the lowest: compounds 1, 2, 3 and 4 (each within the scatter of the next).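

Cycloheptyl in place of 4-methoxyphenyl on an amine nitrogen in a ring gives no change at the digits printed from compound 1 to compound 4 (within the scatter) in this assay and so shows that replacing an aromatic ring carrying a hydrogen-bond acceptor with a non-aromatic ring of carbon only brings no measurable displacement of the labelled ligand into view at this position. As compound 1 already reads at the bottom of the scale, this step can reveal only the absence of a gain, and it cannot show whether cycloheptyl would cost anything on a compound with measurable displacement. Nothing in the data explains why these compounds show no displacement.

On these data alone, whether any group at this position can produce a reading at all stays open, for example a benzyl group or a longer chain ending in a carboxylic acid on the same ring nitrogen. With all the readings level, the compounds shown also give no ranking of the groups at this position.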